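The source may report more compounds than this note shows. Statements on the series, on what has been measured and on what is new or still open speak of the compounds shown alone.

Measured in an ADME assay on QSG7701 cells (Homo sapiens) for inhibition, read by MTT assay, with a stated time of 48 h, tested at 50 uM; a higher number here means a stronger effect of the compound at the concentration tested, a lower number a weaker effect:
compound 1 `O=C(Nc1cccc(Cl)c1)Nc1ccc(-c2cc(=O)c3ccccc3o2)c(Cl)c1` gives 48.9%;
compound 2 `CCc1ccc2oc(-c3ccc(NC(=O)Nc4cccc(Cl)c4)cc3Cl)cc(=O)c2c1` gives 12.6%;
compound 3 `COc1ccc2oc(-c3ccc(NC(=O)Nc4cccc(Cl)c4)cc3Cl)cc(=O)c2c1` gives 15.9%.

Among these three numbers compound 3 stands second highest. Its nearest neighbour is compound 2, separated by a number 3.3 percentage points higher from compound 2 to compound 3 (within the scatter), a gap that lies within the scatter. Its furthest is compound 1: the step of a number 33 percentage points lower from compound 1 to compound 3 (beyond the scatter) is large and comes from methoxy in place of hydrogen on an aromatic carbon of the shared core, as does the similarly large step a number 36.3 percentage points lower from compound 1 to compound 2 (beyond the scatter) from ethyl in place of hydrogen there.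

Compound 4 `COc1ccc2oc(-c3ccc(NC(=O)Nc4ccc(Cl)c(Cl)c4)cc3Cl)cc(=O)c2c1` differs from compound 3 in one place: chloro in place of hydrogen on an aromatic carbon. Neither of the measured steps bears on this change. Within the data shown here, both concern groups on the shared core, and no two measured compounds differ by a chloro group. There is thus no measured guide for the direction or size of the step, and nothing beyond the scatter is expected in this assay. Compound 4 is therefore expected to give 18%, between 5% and 38%. This estimate means an expected step of a number 2.1 percentage points higher from compound 3 to compound 4 (within the scatter).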

Compound 4, a percentage reported as inhibition, at one concentration (the size of the read-out at that concentration, not a potency): 13.2%
Estimate against measurement, compound 4: 4.8 percentage points above; the range from low to high includes it.
By their numbers in this assay, from the lowest: compounds 2, 4 and 3 (each within the scatter of the next); then compound 1.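

In this assay, adding chloro to turn the 3-chlorophenyl group into a 3,4-dichlorophenyl group gives a step of a number 2.7 percentage points lower from compound 3 to compound 4 (within the scatter). Among these compounds, this is the first measured change away from the place on the shared core altered in the earlier steps, and, unlike those large steps from compound 1, it stays within the scatter: with methoxy on the core, a chloro group ortho to the existing chloro group and para to a large group makes no measurable difference here. No available measurement speaks to the reason for this outcome.

From the compounds shown here alone, whether the same chloro group would leave the number as unmoved on the unsubstituted core of compound 1, at 48.9%, remains open. Going by these compounds, how an amine or a carboxylic acid at this position would read in this assay is also open.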